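Trimming the long chain of compound 3

The source may report more compounds than this note shows. Statements on the series, on what has been measured and on what is new or still open speak of the compounds shown alone.

Measured in an ADME assay for permeability, using PAMPA, with a stated time of 12 h, at pH 7.4, tested at 10 uM; a lower number here means that the compound crosses the layer more slowly, a higher number that the compound crosses the layer faster:

- compound 1 `CCCCCCCCCCc1ccc(NC(=O)C(=O)N2C[C@H](Oc3ccc(CCS(=O)(=O)OCC)cc3)[C@H](Oc3ccc(/C=C/S(=O)(=O)OCC)cc3)C2)cc1` gives 1.82 10^-6 cm/s
- compound 2 `CCCCCCCCCCCCc1ccc(NC(=O)C(=O)N2C[C@H](Oc3ccc(CCS(=O)(=O)OCC)cc3)[C@H](Oc3ccc(/C=C/S(=O)(=O)OCC)cc3)C2)cc1` gives 2.26 10^-6 cm/s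
- compound 3 `CCCCCCCCCCCCc1ccc(NC(=O)C(=O)N2C[C@@H](Oc3ccc(/C=C/S(=O)(=O)OCC)cc3)[C@H](Oc3ccc(CCS(=O)(=O)OCC)cc3)C2)cc1` gives 1.74 10^-6 cm/s

These three numbers all lie within the usual scatter of one another, so compound 3 stands level with compounds 1 and 2.

Compound 4 `CCCCCCCCCCc1ccc(NC(=O)C(=O)N2C[C@@H](Oc3ccc(/C=C/S(=O)(=O)OCC)cc3)[C@H](Oc3ccc(CCS(=O)(=O)OCC)cc3)C2)cc1` differs from compound 3 in one place: hydrogen in place of ethyl on a saturated chain carbon, ten or more bonds along the chain from an aromatic carbon. The closest measured guide is the same change run in reverse, with ethyl in place of hydrogen, and it gave a 1.2-fold higher number from compound 1 to compound 2 (0.09 log units; within the scatter). The other measured step, a 1.3-fold lower number from compound 2 to compound 3 (0.11 log units; within the scatter), reflects the fact that compounds 2 and 3 differ only in the configuration as drawn and is just as small. With compound 1 and compound 2 so close, no change beyond the scatter is expected in this assay, only perhaps a slight downward drift. The expected result is a 1.2-fold lower number from compound 3 to compound 4 (0.06 log units; within the scatter). For compound 4 the estimated value is 1.5 10^-6 cm/s, with an expected range from 0.8 10^-6 cm/s to 2.9 10^-6 cm/s.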

Compound 4, apparent permeability: 1.93 10^-6 cm/s
Compound 4: middle estimate off by 1.3-fold (0.11 log units), on the low side; low and high end bracket the measured number.
By their numbers in this assay, from the lowest: compounds 3, 1, 4 and 2 (each within the scatter of the next).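

Taking ethyl off at this place on the chain can now be read on a second core, and in this assay it gives a 1.1-fold higher number from compound 3 to compound 4 (0.05 log units; within the scatter), so the change stays within the scatter on both cores: the same change on two cores in this assay, a 1.2-fold higher number (0.09 log units; within the scatter) from compound 1 to compound 2 and a 1.1-fold lower number (0.05 log units; within the scatter) from compound 4 to compound 3, 1.4-fold (0.14 log units) apart, within the scatter of two such steps. Changing the drawn configuration at one ring stereocentre can now be read with the shorter chain as well, and it gives a 1.1-fold higher number from compound 1 to compound 4 (0.03 log units; within the scatter), again within the scatter: the fact that compounds 1 and 4 differ only in the configuration as drawn. Among these compounds, the four compounds thus cover both chain lengths with both configurations, and no step among them lies beyond the scatter.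

As far as these compounds go, it remains open whether a longer chain would shift the number beyond the scatter. The same question applies to a carboxylic acid or an amine carried at this place on the chain.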